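Series notes: three flat readings and one untested amide

The source may report more compounds than this note shows. Statements on the series, on what has been measured and on what is new or still open speak of the compounds shown alone.

Values come from an assay on isolated protein for inhibition of Rho-associated protein kinase 2 (Homo sapiens), read by HTRF, tested at 10 uM; a higher number here means more inhibition at the concentration tested (going by the name of the read-out), a lower number less inhibition.

compound 1 `COC[C@@H]1CCCN1C(=O)C1CCCN1c1cc(Nc2cccc(Br)c2)ncn1`: 0%
compound 2 `Cc1cccc(N(C)c2cc(Nc3cccc(C(=O)N(CC(C)C)CC(C)C)c3)ncn2)c1`: 0%
compound 3 `Cc1cccc(Oc2ccnc(N3CCN(C(=O)c4c(C)noc4C)CC3)n2)c1`: 0%

Compound 3 stands level with compounds 1 and 2 at the digits shown; its nearest neighbour in the numbers is compound 1, with no change at the digits shown, and its furthest is compound 2, again with no change at the digits shown, both within the scatter. No pair of these compounds is separated by a single-site change, so nothing can be said of any one step among them beyond what the three values show, and all three show the same reading.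

Compound 4 `CC(=O)CCCCC(=O)N1CCN(c2nccc(Oc3cccc(C)c3)n2)CC1` is the next entry, unmeasured. Relative to compound 3 it carries 4-acetylbutyl in place of 3,5-dimethyl-1,2-oxazol-4-yl on a carbonyl carbon. The change sits on the carbonyl carbon attached to the amide-type nitrogen in a ring; everything else is kept.

Going by the values given here, with compound 3 at 0% and no compound in the set showing any reading above the scatter, the expected step of no change at the digits printed from compound 3 to compound 4 (within the scatter) is none beyond the scatter, in no particular direction. Compound 4 is accordingly estimated at 0%, with a range from -8% to 10%.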

Compound 4, a percentage reported as inhibition, at one concentration (the size of the read-out at that concentration, not a potency): 0%
Estimate against measurement, compound 4: no gap at the digits printed, and the stated range covers the measured number.
By their numbers in this assay, from the lowest: compounds 1, 2, 3 and 4 (each within the scatter of the next).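

Read in this assay the replacement of 3,5-dimethyl-1,2-oxazol-4-yl by 4-acetylbutyl on the carbonyl carbon gives no change at the digits printed from compound 3 to compound 4 (within the scatter) and is the first single-site step available in the series. At this position, a five-membered aromatic ring with two hetero atoms and an open chain with no ring, each of seven heavy atoms, give the same reading, even though the chain carries one hydrogen-bond acceptor to the ring's two. No measurement on hand explains this flat result.

Since neither compound gives a reading above zero, this step cannot show whether the position matters in a compound with measurable inhibition. From the compounds shown here alone, whether a carboxylic acid, an amine or a longer chain on this carbonyl carbon would give a reading beyond the scatter remains open.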